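The compounds below may be only part of what the source reports. "The series", "measured", "known", "first", "only" and "open" are said of these compounds alone.

Measured so far:
compound 1 `CCN(CC)C(=S)SCC1=CCOC1=O`, 121000 nM
compound 2 `CNC(=S)SCC1=CCOC1=O`, 83100 nM

Both numbers come from a functional assay on MCF7 cells (Homo sapiens) for antiproliferative activity, read by MTT assay, with a stated time of 72 h; on this read-out lower numbers stand for stronger inhibition and higher numbers for weaker inhibition. Among the compounds with values here, compound 2 and compound 1 sit within the scatter of each other; the one step known, a 1.5-fold lower number from compound 1 to compound 2 (0.16 log units; within the scatter), swaps the amine on the thiocarbonyl carbon without moving the read-out beyond the scatter.

Compound 3 `CC(C)NC(=S)SCC1=CCOC1=O` is the next point: isopropyl in place of methyl on an amide-type nitrogen, again a change of the amine only. Within the data shown here, the single step bearing on it was small, so no shift beyond the scatter is expected in this assay. The estimate for compound 3 is 80000 nM, range 35000 nM to 190000 nM, meaning an expected step of a 1.0-fold lower number from compound 2 to compound 3 (0.02 log units; within the scatter).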

Compound 3, half-maximal inhibitory concentration: 134000 nM
Beside the measured number, compound 3's estimate is 1.7-fold (0.22 log units) below it; low and high end bracket the measured number.
By their numbers in this assay, from the lowest: compounds 2, 1 and 3 (each within the scatter of the next).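

In this assay, isopropyl in place of methyl on the amide-type nitrogen stays within the scatter (a 1.6-fold higher number from compound 2 to compound 3 (0.21 log units; within the scatter)), and isopropylamino in place of diethylamino on the thiocarbonyl carbon also stays within it (a 1.1-fold higher number from compound 1 to compound 3 (0.04 log units; within the scatter)). Across methylamino, isopropylamino and diethylamino, this position therefore shows no step beyond the scatter. Nothing available bears on why.

Still open, from the compounds shown here alone, is whether a phenyl group or a longer chain on this nitrogen would give a step beyond the scatter. Changes to the shared core also remain open.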